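Adding a Fluoro Group to an Inactive Benzimidazole Acid

The compounds below may be only part of what the source reports. "The series", "measured", "known", "first", "only" and "open" are said of these compounds alone.

Measured so far:
Compound 1 `O=C(O)CC(Cc1nc2cc(Cl)ccc2[nH]1)c1ccc(Cl)cc1`: 0%
Compound 2 `N#Cc1ccc2[nH]c(CC(CC(=O)O)c3ccc(Cl)cc3)nc2c1`: 0%

In an assay on isolated protein for inhibition of protein kinase C zeta type (Homo sapiens), read by 33P incorporation, tested at 50 uM (a higher number here means a stronger effect of the compound at the concentration tested, a lower number a weaker effect), compound 1 gives 0%, and compound 2 gives 0%. Among the measured compounds shown here, compound 1 thus stands level with compound 2, and the single measured step, no change at the digits printed from compound 1 to compound 2 (within the scatter), shows that the one change tried so far left the read-out unmoved. Compound 3 `O=C(O)CC(Cc1nc2cc(Cl)ccc2[nH]1)c1ccc(Cl)c(F)c1` differs from compound 1 by fluoro in place of hydrogen on an aromatic carbon. For the measured compounds named here, no measured step concerns this change, and the only step known, no change at the digits printed from compound 1 to compound 2 (within the scatter), gave nothing beyond the scatter. The expected step of no change at the digits printed from compound 1 to compound 3 (within the scatter) is accordingly none beyond the scatter. Compound 3 is estimated to give 0%, between -8% and 10%.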

Compound 3, a percentage reported as inhibition, at one concentration (the size of the read-out at that concentration, not a potency): 0%
Beside the measured number, compound 3's estimate shows no gap at the digits printed; the measured number falls inside the stated range.
By their numbers in this assay, from the lowest: compounds 1, 2 and 3 (each within the scatter of the next).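

In this assay, replacing 4-chlorophenyl with 4-chloro-3-fluorophenyl brings no change at the digits printed from compound 1 to compound 3 (within the scatter) for this aromatic carbon ortho to a chloro group. Among the compounds shown here, the earlier step changed a different place, so this is the first reading at this ring, and a fluoro group in place of hydrogen does not lift the compound from its inactive level. Nothing measured offers an explanation for this result. Still open, as far as these compounds go, is whether a larger group on this ring, such as an amine or a methoxy group, would give any inhibition. From the compounds shown here alone, an amide in place of the carboxylic acid is equally open.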